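This account rests on a few compounds, and the source may have more. Where it says the series, first, only, none or still open, it means among the compounds named here.

Measured compounds in an assay (Equus caballus) for inhibition of Thromboxane-A synthase (Homo sapiens), using microsomes; on this read-out lower numbers stand for stronger inhibition and higher numbers for weaker inhibition:
compound 1 `C=C(C)C(CCC/C=C(\c1ccccc1)c1cccnc1)C(=O)O` gives 28 nM;
compound 2 `CC(C)CSC(CCC/C=C(\c1ccccc1)c1cccnc1)C(=O)O` gives 110 nM;
compound 3 `C=CCC(CCC/C=C(\c1ccccc1)c1cccnc1)C(=O)O` gives 50 nM.

Compound 3 stands second highest of the three numbers. Its nearest neighbour is compound 1, which lies within the scatter of it, as the step of a 1.8-fold higher number from compound 1 to compound 3 (0.25 log units; within the scatter) shows; the step of a 2.2-fold lower number from compound 2 to compound 3 (0.34 log units; beyond the scatter) is beyond the scatter, so compound 2 is the furthest of the three from compound 3.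

Compound 4 `O=C(O)C(CCC/C=C(\c1ccccc1)c1cccnc1)C1(O)CCCC1` is not yet measured. It differs from compound 3 only in that (1-hydroxycyclopentyl in place of allyl on a saturated chain carbon bound to a carbonyl carbon and a saturated chain carbon).

Going by the values given here, two measured steps touch the same position and bear on this change. The step of a 1.8-fold higher number from compound 1 to compound 3 (0.25 log units; within the scatter) shows that exchanging one small carbon-only chain for another at this carbon moves the number little. The step of a 3.9-fold higher number from compound 1 to compound 2 (0.59 log units; beyond the scatter) shows that a larger group carrying a heteroatom at this carbon raises the number. The group that enters in compound 4 is again larger than allyl and carries an oxygen, so a modest rise in this assay is expected rather than none, in the direction of weaker inhibition, roughly a 2.0-fold higher number from compound 3 to compound 4 (0.30 log units; within the scatter).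

For compound 4 the expected value in this assay is 100 nM, with a range from 35 nM to 300 nM.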

Compound 4, half-maximal inhibitory concentration: 65 nM
Estimate against measurement, compound 4: 1.5-fold (0.19 log units) above; low and high end bracket the measured number.
By their numbers in this assay, from the lowest: compounds 1, 3, 4 and 2 (each within the scatter of the next, the first and the last beyond it).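

In this assay, going by these compounds alone, the earlier compounds carried only open-chain groups at this saturated chain carbon, and 1-hydroxycyclopentyl now shows that a group with a five-membered non-aromatic ring of carbon only, a hydrogen-bond donor and a hydrogen-bond acceptor can stand there, with a 1.3-fold higher number from compound 3 to compound 4 (0.11 log units; within the scatter) and so no separation from allyl. Compound 4 is equally inseparable from the isobutylsulfanyl compound, with a 1.7-fold lower number from compound 2 to compound 4 (0.23 log units; within the scatter), yet the 1-methylethenyl compound remains apart, with a 2.3-fold higher number from compound 1 to compound 4 (0.37 log units; beyond the scatter), so compound 4 falls within the scatter of two compounds that are themselves separated, and a larger group carrying a heteroatom at this carbon does not by itself give a step beyond the scatter from allyl. Nothing at hand gives a cause for these steps.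

Going by these compounds, whether the ring or the oxygen of 1-hydroxycyclopentyl governs this result stays open, and a plain cyclopentyl group or an open-chain hydroxyalkyl group at this carbon would separate the two. Also open, on these data alone, is how an amine at the same carbon would read out against these groups.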